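The source may hold more compounds than are shown below. What is called first, only, known or untested is meant among the compounds shown, and "the series" means these compounds.

Compound 2 `O=C1CSC(c2ccc(Cl)cc2)N1CCN1CCCCC1` was tested in an ADME assay on Vero cells (Chlorocebus sabaeus) for cytotoxicity, read by neutral red uptake, tested at 3150 ug/mL (on this read-out higher numbers stand for a weaker effect at the one concentration tested and lower numbers for a stronger effect), and gives 11%. Going by the values given here, the only other compound with a number here is compound 1 `O=C1CSC(c2cccc(F)c2)N1CCN1CCCCC1`, which in this assay gives 13%. The step between them, a number 2 percentage points lower from compound 1 to compound 2 (within the scatter), lies within the scatter, so the two compounds stand together, and nothing separates compound 2 from compound 1 on these numbers.

Compound 3 `O=C1CSC(c2ccc([N+](=O)[O-])cc2)N1CCN1CCCCC1` has not yet been measured. It differs from compound 2 in one place: nitro in place of chloro on an aromatic carbon.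

Among the compounds with values here, the one measured step that bears on this change is a number 2 percentage points lower from compound 1 to compound 2 (within the scatter), an exchange of one group on the aromatic ring for another, and it moved the number only within the scatter. That is a single step, so it is thin ground, but it gives no sign that a change on this ring moves the read-out. The expectation is therefore a step of about a number 1 percentage points higher from compound 2 to compound 3 (within the scatter), which means no shift beyond the scatter in either direction.

For compound 3 the expected value in this assay is 12%, with a range from 3% to 25%.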

Compound 3, a percentage reported as activity, at one concentration (the size of the read-out at that concentration, not a potency): 10%
Estimate against measurement, compound 3: 2 percentage points above; the measured number falls inside the stated range.
By their numbers in this assay, from the lowest: compounds 3, 2 and 1 (each within the scatter of the next).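

In this assay, nitro in place of chloro on an aromatic carbon, para to a large group, gives a number 1 percentage points lower from compound 2 to compound 3 (within the scatter) and leaves compound 2 and compound 3 standing together. The earlier step only exchanged one halogen-bearing ring for another, whereas here a single chlorine atom gives way to a group of three heavy atoms with two hydrogen-bond acceptors, and the read-out still does not separate the two compounds, so this position now has a second exchange that stays within the scatter. No measurement shown gives a reason for this result.

As far as these compounds go, the groups on this ring so far are fluoro, chloro and nitro, so it remains open whether an amine, a carboxylic acid or a methoxy group on the same ring carbon would move the number beyond the scatter. The shared core and its side chain are the same in all the compounds shown, so what a longer chain there would do also remains open.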